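The source may hold more compounds than are shown below. What is called first, only, known or untested is meant among the compounds shown, and "the series" means these compounds.

Of the compounds shown here, three sharing one core have been tested in an assay on CHO cells for displacement of a labelled ligand from adenosine receptor A3 (Homo sapiens), read by scintillation counting, with a stated time of 60 min; a lower number here means a stronger inhibitor, a higher number a weaker inhibitor. Compound 1 `Cc1nc(NC(=O)c2ccccc2)c2nn(-c3ccccc3)cc2n1` gives 5.6 nM in this assay. Compound 2 `O=C(Nc1nc(-c2ccccc2)nc2cn(-c3ccccc3)nc12)c1ccco1` gives 24 nM, and compound 3 `COc1ccc(-n2cc3nc(-c4ccccc4)nc(N)c3n2)cc1` gives 75 nM. Among these three numbers compound 2 holds the second highest: its number lies above that of compound 1 and below that of compound 3, and both of those gaps are beyond the usual scatter of repeated measurements.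

Compound 4 `O=C(c1ccco1)N(C(=O)c1ccco1)c1nc(-c2ccccc2)nc2cn(-c3ccccc3)nc12` has not been measured yet. It differs from compound 2 in one place: (furan-2-yl)carbonyl in place of hydrogen on an amide-type nitrogen. Within the data shown here, no single-point step between two measured compounds is known here, so there is no measured precedent for this kind of change on this core. Putting a (furan-2-yl)carbonyl group in place of the amide hydrogen leaves that nitrogen of compound 2 without a hydrogen, and an expected outcome is a moderately higher number in this assay, beyond the scatter but not large. The step is estimated as a 2.9-fold higher number from compound 2 to compound 4 (0.46 log units; beyond the scatter). Compound 4 is expected to give about 70 nM, within a range from 20 nM to 300 nM.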

Compound 4, inhibition constant: 75 nM
Compound 4: middle estimate off by 1.1-fold (0.03 log units), on the low side, and the stated range covers the measured number.
By their numbers in this assay, from the lowest: compound 1; then compound 2; then compounds 3 and 4 (each within the scatter of the next).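

In this assay, putting a (furan-2-yl)carbonyl group in place of the amide hydrogen gives a 3.1-fold higher number from compound 2 to compound 4 (0.49 log units; beyond the scatter), the first measured change at a single place among these compounds. The step is beyond the usual scatter but modest, so this amide-type nitrogen can lose its hydrogen and carry this second, larger group without the compound losing its measurable activity. Even with two (furan-2-yl)carbonyl groups on that nitrogen, compound 4 still gives 75 nM.

Going by these compounds, whether a methyl or an acetyl group on this nitrogen would give a step of similar size stays open, as does whether the same change would have a similar effect on compound 1. The compounds and numbers shown offer no measured explanation for this step.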